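From 4-methoxyphenyl to 4-bromophenyl: working notes

This account rests on a few compounds, and the source may have more. Where it says the series, first, only, none or still open, it means among the compounds named here.

Values so far in a functional assay on MIA PaCa-2 cells (Homo sapiens) for inhibition, read by MTT assay, with a stated time of 72 h, tested at 50 uM (on this read-out higher numbers stand for more inhibition of growth at the one concentration tested and lower numbers for less inhibition of growth), are these
compound 1 `C=CCc1ccc(OCc2cn(-c3cccc([N+](=O)[O-])c3)nn2)c(O)c1` gives 58.8%
compound 2 `C=CCc1cc(O)c(O)c(CN2CCC(C)CC2)c1` gives 90.6%
compound 3 `C=CCc1ccc(OCc2cn(-c3ccc(OC)cc3)nn2)c(O)c1` gives 88.2%

In this assay compound 3 cannot be told apart from compound 2, as the two values lie within the scatter of each other. Compound 3 stands clearly above compound 1, with a gap well beyond the scatter.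

The next compound to be read is compound 4 `C=CCc1ccc(OCc2cn(-c3ccc(Br)cc3)nn2)c(O)c1` and its difference from compound 3 is bromo in place of methoxy on an aromatic carbon in a single place. In words, this is bromo in place of methoxy on an aromatic carbon, para to a large group.

For the measured compounds named here, no measured pair isolates this change, so the data give no direct size for it. A moderate loss of growth inhibition is expected in this assay although a result within the scatter of compound 3 cannot be excluded. Going by the values given here, the only guide is the span between compound 1 at 58.8% and compound 3 at 88.2% and the estimate is placed inside that span.

The expected change is a number 16.2 percentage points lower from compound 3 to compound 4 (beyond the scatter) on this estimate. For compound 4 the estimated value is 72% with an expected range from 56% to 88% in this read-out.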

Compound 4, percent growth inhibition at one concentration: 47.3%
Estimate against measurement, compound 4: 24.7 percentage points above; measured number below the stated range.
By their numbers in this assay, from the lowest: compound 4; then compound 1; then compounds 3 and 2 (each within the scatter of the next).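

In this assay the series now has its first step that isolates a single place: a number 40.9 percentage points lower from compound 3 to compound 4 (beyond the scatter) for 4-methoxyphenyl to 4-bromophenyl. The outcome of the assay therefore depends on what sits on this aromatic carbon, para to a large group, and a one-group exchange there is enough to produce a large step while the rest of the structure stays the same. In counted terms, methoxy with its two heavy atoms and one hydrogen-bond acceptor leaves and bromo with one heavy atom and no hydrogen-bond acceptor enters, but no measurement at hand bears on why the number falls, so the step stands as an observation only.

A single pair cannot show whether the fall follows from losing methoxy or from gaining bromo, and a plain hydrogen, chloro or ethoxy at this place would help to separate the two readings. Going by these compounds, how far the position tolerates other kinds of group also remains open, for instance an amine or a carboxylic acid in the same para place on the same core.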